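The compounds below may be only part of what the source reports. "The series", "measured", "known", "first", "only" and "open" are said of these compounds alone.

Of the compounds shown here, three have been tested so far in a functional assay on PC-3 cells (Homo sapiens) for cytotoxicity, read by MTT assay, with a stated time of 72 h; a higher number here means a weaker inhibitor, a lower number a stronger inhibitor. Compound 1 `O=C(c1ccccc1)c1sc(N2CCCC2)nc1Br` gives > 100000 nM, which is a limit of the assay and not a number. Compound 2 `N#Cc1sc(N2CCCCC2)nc1Br`, which carries a piperidin-1-yl group on a different core, gives > 100000 nM, again a limit and not a number. Going by the values given here, compound 3 `COC(=O)c1sc2nc(SC)sc2c1C` gives 90000 nM, the only true number among the three, so it is the single firm reference point.

Compound 4 `COC(=O)c1sc2nc(N3CCCCC3)sc2c1C` keeps the core of compound 3 and alters one group, with piperidin-1-yl in place of methylsulfanyl on an aromatic carbon. This group sits next to the ring nitrogen and next to the ring sulfur. Among the compounds with values here, no measured pair of compounds shows what a single change of this kind does, so the expectation has to stay close to the reference point. Compound 3, at 90000 nM, anchors that expectation. Compound 4 could also end up reported only as a limit.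

The expected shift is a 1.1-fold lower number from compound 3 to compound 4 (0.05 log units; within the scatter), a change no larger than the usual scatter and so without a meaningful direction. For compound 4 the estimated value is 80000 nM, with an expected range from 25000 nM to 100000 nM.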

Compound 4, half-maximal inhibitory concentration: 93000 nM
Estimate against measurement, compound 4: 1.2-fold (0.07 log units) below; low and high end bracket the measured number.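

Replacing methylsulfanyl with piperidin-1-yl on this aromatic carbon, next to the ring nitrogen and next to the ring sulfur, gives a 1.0-fold higher number from compound 3 to compound 4 (0.01 log units; within the scatter). Going by these compounds alone, this is the first single change that can be read in this assay, and it shows that a six-membered non-aromatic ring can take the place of a two-atom group here with no measurable effect on the reading. The result is only weak evidence that this position tolerates change in general, because the numbers for compound 3 and compound 4 lie close to the top of the reported range, where compound 1 and compound 2 appear only as a limit and not as a number: the limit of > 100000 nM in this assay, at which 2 of the 4 values shown sit.

Going by these compounds, it remains open whether any group on this carbon can bring the number well down, for example a primary amine, a morpholine ring or a longer alkyl chain ending in an amine. On these data alone, the effect of changing the rest of the shared core, such as replacing the methyl ester with a carboxylic acid or an amide, also remains open.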